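The compounds below may be only part of what the source reports. "The series", "measured", "known", "first", "only" and "open" are said of these compounds alone.

Compound 1 `CNC(=O)c1cc(Oc2ccc(NC(=O)c3cc(-c4ccc(C(F)(F)F)cc4)ncn3)cc2F)ccn1` is the starting point of this account. In a functional assay on PC-3 cells (Homo sapiens) for cytotoxicity, read by MTT assay, with a stated time of 72 h (on this read-out higher numbers stand for weaker inhibition and lower numbers for stronger inhibition), compound 1 gives > 100000 nM, which is a limit of the assay rather than a measured number. The companion compound 2 `CNC(=O)c1cc(Oc2ccc(NC(=O)c3cc(-c4ccc(Cl)cc4)ncn3)cc2)ccn1` stands in the same position: in this assay compound 2 gives > 100000 nM, again a limit and not a number. Taken together, the two values shown sit at the limit of > 100000 nM in this assay, at which 2 of the 2 values shown sit, so nothing within the data separates one from the other, and compound 1 cannot be placed anywhere except at that limit.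

The unmeasured compound 3 `CNC(=O)c1cc(Oc2ccc(NC(=O)c3cc(-c4ccc(F)cc4)ncn3)cc2F)ccn1` differs from compound 1 in one place, by fluoro in place of trifluoromethyl on an aromatic carbon. Going by the values given here, no step between two measured compounds is available, so the size of this change on the read-out has not been seen. With both measured compounds at the limit, the expectation is that the change from trifluoromethyl to fluoro brings no movement beyond the scatter, and that compound 3 most likely also returns a limit. Compound 3 is therefore estimated at 150000 nM, with a range from 30000 nM to 1000000 nM. The expected step is a step that the limit leaves unreadable from compound 1 to compound 3.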

Compound 3, half-maximal inhibitory concentration: > 100000 nM
Compound 3 was reported as a limit; the forecaster's own chance of this, stated with the estimate: 80%; the middle value lies beyond the limit too.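

In this assay compound 3 gives > 100000 nM, which is a limit and not a number. Going by these compounds alone, no step from compound 1 to compound 3 can be read, because both ends are limits: the limit of > 100000 nM in this assay, at which 3 of the 3 values shown sit. The compounds shown leave open whether any change to the shared core would return a measured number in this assay.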